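The source may report more compounds than this note shows. Statements on the series, on what has been measured and on what is new or still open speak of the compounds shown alone.

Measured so far:
- compound 1 `O=C(Nc1cccc(-n2cc(-c3ccncc3)c(-c3cc(O)cc(Cl)c3)n2)c1)Nc1ccc(Cl)c(C(F)(F)F)c1`: 93%
- compound 2 `COc1cc(Cl)cc(-c2nn(-c3cccc(NC(=O)Nc4ccc(Cl)c(C(F)(F)F)c4)c3)cc2-c2ccncc2)c1`: 91%
- compound 3 `COc1cc(Cl)cc(-c2nn(-c3cccc(NC(=O)Nc4cc(C(F)(F)F)cc(C(F)(F)F)c4)c3)cc2-c2ccncc2)c1`: 79%

In a functional assay on UO-31 cells (Homo sapiens) for inhibition, read by sulforhodamine B assay, with a stated time of 48 h, tested at 0.01 uM (on this read-out higher numbers stand for a weaker effect at the one concentration tested and lower numbers for a stronger effect), compound 2 gives 91%, the second highest of the three numbers. Compound 1 stands nearest, with a number 2 percentage points lower from compound 1 to compound 2 (within the scatter). Going by the values given here, compound 3 lies furthest, and its reading of 79% is beyond the scatter from that of compound 2; no single-point step connects these two, so only the two values themselves are on hand.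

Compound 4 `COc1cc(Cl)cc(-c2nn(-c3cccc(NC(=O)Nc4cccc(C(F)(F)F)c4)c3)cc2-c2ccncc2)c1` has not yet been measured. It differs from compound 2 as follows: hydrogen in place of chloro on an aromatic carbon. Among the compounds with values here, the only measured step, from compound 1 to compound 2, concerns the oxygen on the other aromatic ring and lies within the scatter; it says nothing about the chloro ortho to the trifluoromethyl group. Within the data shown here, with no step bearing on this change, the working expectation is that compound 4 stays close to compound 2, the expected step being a number 1 percentage points higher from compound 2 to compound 4 (within the scatter). In this assay compound 4 is therefore estimated at 92%, within 82% to 100%.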

Compound 4, a percentage reported as activity, at one concentration (the size of the read-out at that concentration, not a potency): 91%
Compound 4: middle estimate off by 1 percentage points, on the high side; low and high end bracket the measured number.
By their numbers in this assay, from the lowest: compound 3; then compounds 2, 4 and 1 (each within the scatter of the next).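

In this assay hydrogen in place of chloro gives no change at the digits printed from compound 2 to compound 4 (within the scatter) and so, at this carbon, ortho to a trifluoromethyl group and para to a large group, the two substituents are not told apart at the one concentration tested. On the same ring, hydrogen in place of trifluoromethyl at a different carbon gives a number 12 percentage points higher from compound 3 to compound 4 (beyond the scatter) and so this ring is not silent to every change, although the response is modest and rests on one pair. Nothing on hand accounts for either step.

On these data alone, whether a group other than chloro at this carbon, such as methoxy, an amine or a carboxylic acid, would shift the reading stays open. So does whether the chloro makes any difference at higher concentrations, where the read-out might no longer sit so close to that of the other compounds.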